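A few compounds are considered here, and "the series" means these few. Any claim that something is new, unique, unknown or untested is made for them only; others in the source may bear on it.

Among the compounds with values here, compound 1 `FC(F)(F)c1ccc2[nH]c(-c3ccccc3)nc2c1` is one of two compounds measured in a functional assay for antagonist activity at Neuropeptides B/W receptor type 1 (Homo sapiens), read by cAMP accumulation (a higher number here means a weaker inhibitor, a lower number a stronger inhibitor), where compound 1 gives 1200 nM. The other is compound 2 `O=[N+]([O-])c1ccc2nc(-c3ccc(Cl)cc3Cl)[nH]c2c1`, which in this assay gives 2880 nM. Compound 1 thus has the lower of the two numbers, and its gap to compound 2 lies beyond the usual scatter of repeated measurements.

Compound 3 `Cn1cc(-c2ccc(-c3nc4cc(C(F)(F)F)ccc4[nH]3)cc2)cn1` has not yet been measured. It differs from compound 1 in one place: 1-methyl-1H-pyrazol-4-yl in place of hydrogen on an aromatic carbon, on an aromatic carbon of a six-membered aromatic ring of carbon only.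

Within the data shown here, no pair of measured compounds separated by a single change is available, so no measured step guides the expectation. The step of a 2.0-fold lower number from compound 1 to compound 3 (0.30 log units; within the scatter) is expected to be modest and toward a lower number, though it may not exceed the scatter. Compound 3 is therefore estimated at 600 nM, with a plausible range from 150 nM to 2400 nM.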

Compound 3, half-maximal inhibitory concentration: 1470 nM
For compound 3 the middle estimate is 2.5-fold (0.39 log units) below the measured one, and the stated range covers the measured number.
By their numbers in this assay, from the lowest: compounds 1, 3 and 2 (each within the scatter of the next, the first and the last beyond it).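

In this assay, putting 1-methyl-1H-pyrazol-4-yl in place of hydrogen on this aromatic carbon gives a 1.2-fold higher number from compound 1 to compound 3 (0.09 log units; within the scatter). This is the first single change shown for the series, and it indicates that this position, para to a large group, can carry a substituent of 6 heavy atoms, including a five-membered aromatic ring, without a shift that can be told from the scatter. No measurement on hand explains why the added ring leaves the number within the scatter.

On these data alone, whether a different group on the same carbon, such as an amine, a carboxylic acid or a longer chain, would move the number beyond the scatter remains open. As far as these compounds go, it is also open whether the methyl on the pyrazole contributes anything, since one substituent at one position cannot settle that.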